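This account rests on a few compounds, and the source may have more. Where it says the series, first, only, none or still open, it means among the compounds named here.

Compound 1 `CC(C)(CN)C(CN)C(=O)O` is the starting point in an assay for inhibition of Ornithine decarboxylase (Rattus norvegicus); on this read-out lower numbers stand for stronger inhibition and higher numbers for weaker inhibition. In this assay compound 1 gives > 11000000 nM, a limit rather than a number. That reading is the limit of > 11000000 nM in this assay, at which 2 of the 3 values shown sit. Compound 2 `CC(C)(CN)C(C)(CN)C(=O)O` gives > 11000000 nM in this assay, again a limit. The step that the two limits leave unreadable from compound 1 to compound 2 is therefore unreadable. Compound 3 `CC(CN)C(C)CN`, a diamine without carboxy, gives 6100000 nM in this assay. Compound 4 `CC(CN)C(C)(C)CN` differs from compound 1 by methyl in place of carboxy on a saturated chain carbon bound to two saturated chain carbons, which likewise removes the carboxy. Within the data shown here, no measured step covers this exact change; the only guide is that compound 3 alone returns a number. Compound 4 is therefore expected near compound 3, with the step of an at least 2.2-fold lower number from compound 1 to compound 4 (0.34 log units; beyond the scatter) estimated toward stronger inhibition. The estimate for compound 4 is 5000000 nM, from 1000000 nM to 20000000 nM.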

Compound 4, inhibition constant: > 10500000 nM
Compound 4 was reported as a limit; the forecaster's own chance of this, stated with the estimate: 35%; middle value at least 2.1-fold (0.32 log units) from the limit.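

Compound 4 lacks the carboxy and still reads only as a limit, so losing the carboxy does not by itself return a number: the limit of > 10500000 nM in this assay, at which 1 of the 4 values shown sits. Methyl in place of hydrogen on a saturated chain carbon bound to three saturated chain carbons gives an at least 1.7-fold higher number from compound 3 to compound 4 (0.23 log units; that floor lies within the scatter), and that figure is only a floor. The steps to compound 4 from compound 1 and from compound 2 cannot be read, as limits stand at both ends.

On these data alone, whether hydroxyl or an amide in place of carboxy on this carbon would return a number stays open. So does the true value of compound 4 beyond its limit.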